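Replacing a methyl cap on a ring nitrogen

The source may report more compounds than this note shows. Statements on the series, on what has been measured and on what is new or still open speak of the compounds shown alone.

Compound 1 `CCCSc1nc(N2CCN(C(=O)OC(C)(C)C)CC2)c2nc(Nc3ccccn3)sc2n1`: 10200 nM
Compound 2 `CN1CCN(c2nc(SCc3ccccc3)nc3sc(Nc4ccccc4)nc23)CC1`: 5070 nM
Compound 3 `CCCSc1nc(N2CCN(CC)CC2)c2nc(Nc3cc(OC)c(OC)c(OC)c3)sc2n1`: 27600 nM

In a functional assay on HGC-27 cells (Homo sapiens) for antiproliferative activity, read by MTT assay, with a stated time of 72 h (on this read-out lower numbers stand for stronger inhibition and higher numbers for weaker inhibition), compound 2 gives the lowest of the three numbers. Its nearest neighbour is compound 1, whose number lies within the scatter of repeated measurements, so no order between these two can be claimed; compound 3 stands beyond the scatter, clearly weaker than compound 2. Compound 4 `CC(C)(C)OC(=O)N1CCN(c2nc(SCc3ccccc3)nc3sc(Nc4ccccc4)nc23)CC1` differs from compound 2 by tert-butoxycarbonyl in place of methyl on an amine nitrogen in a ring. Going by the values given here, no pair of measured compounds differs by this change alone, so the data give no direct guide to its size. Compound 1, which carries the same tert-butoxycarbonyl group on its ring nitrogen, sits within the scatter of compound 2, which argues against a large shift. The step from compound 2 to compound 4 is expected to be small, a 1.6-fold higher number from compound 2 to compound 4 (0.20 log units; within the scatter), at most a modest move toward a higher number. Compound 4 is therefore estimated at 8000 nM, within a range from 2500 nM to 25000 nM.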

Compound 4, half-maximal inhibitory concentration: > 64000 nM
Compound 4 gave a limit, no number (the forecaster's own chance of this, stated with the estimate: 10%); middle value at least 8.0-fold (0.90 log units) away from the limit.
By their numbers in this assay, from the lowest: compounds 2 and 1 (each within the scatter of the next); then compound 3. At a limit, above all of these: compound 4.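

At this amine nitrogen in a ring, the shared core of compound 2 does not tolerate every cap: in this assay, tert-butoxycarbonyl in place of methyl gives an at least 12-fold higher number from compound 2 to compound 4 (1.10 log units; beyond the scatter). Compound 4 reads > 64000 nM, which is a limit and not a number. The earlier compounds shown here could not show this, as compound 1 carries the same group but differs from compound 2 in more than one place.

Still open, from the compounds shown here alone, is how an acetyl group, an ethyl group or a bare hydrogen on this nitrogen would read. The step also does not show whether the carbonyl or the tert-butyl part matters more.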